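The compounds below may be only part of what the source reports. "The series", "measured", "known", "first", "only" and "open" are said of these compounds alone.

Three compounds that share one core have been run through an ADME assay on microsomes from liver (Rattus norvegicus, strain Sprague-Dawley) for metabolic stability, read by HPLC, using NADPH, with stated times of 5 min and 60 min, tested at 10 uM; a higher number here means faster removal of the compound, a lower number slower removal. Compound 1, `CS(=O)(=O)Nc1ccc(CNC(=O)c2ccc(C(F)(F)F)cc2)c(Cl)c1`, gives 9.6 mL.min-1.g-1 in this assay. Compound 2, `CS(=O)(=O)Nc1ccc(CNC(=O)c2ccc(N3CCC3)cc2)c(Cl)c1`, gives 8.6 mL.min-1.g-1, and compound 3, `CC(C)Oc1ccc(C(=O)NCc2ccc(NS(C)(=O)=O)cc2Cl)cc1`, gives 12 mL.min-1.g-1. Compound 1 holds the second highest of these three numbers, yet all three sit close together: the step of a 1.1-fold lower number from compound 1 to compound 2 (0.05 log units; within the scatter) and the step of a 1.3-fold higher number from compound 1 to compound 3 (0.10 log units; within the scatter) each lie within the scatter, as does a 1.4-fold higher number from compound 2 to compound 3 (0.14 log units; within the scatter). Compound 4, `CS(=O)(=O)Nc1ccc(CNC(=O)c2ccc(CC(F)(F)F)cc2)c(Cl)c1`, has not been measured. It differs from compound 1 in one place: 2,2,2-trifluoroethyl in place of trifluoromethyl on an aromatic carbon. For the measured compounds named here, none of the measured steps swaps trifluoromethyl for 2,2,2-trifluoroethyl, so the only guides are the two measured steps that start from compound 1, a 1.1-fold lower number from compound 1 to compound 2 (0.05 log units; within the scatter) and a 1.3-fold higher number from compound 1 to compound 3 (0.10 log units; within the scatter), both of which stayed within the scatter. The expected step of a 1.1-fold higher number from compound 1 to compound 4 (0.06 log units; within the scatter) is therefore small, with no direction that should rise above the scatter. Compound 4 is estimated at 11 mL.min-1.g-1 in this assay, within a range from 6 mL.min-1.g-1 to 20 mL.min-1.g-1.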

Compound 4, intrinsic clearance in microsomes: 22 mL.min-1.g-1
Beside the measured number, compound 4's estimate is 2.0-fold (0.30 log units) below it, outside the stated range (above it).
By their numbers in this assay, from the lowest: compounds 2, 1, 3 and 4 (each within the scatter of the next, the first and the last beyond it).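

Until now, no swap at this position, on an aromatic carbon para to a large group, had moved the number in this assay beyond the scatter, so the position could have seemed insensitive to what sits there. The step to 2,2,2-trifluoroethyl, a group with one carbon more than trifluoromethyl, breaks that picture with a modest but real change (a 2.3-fold higher number from compound 1 to compound 4 (0.36 log units; beyond the scatter)), and the same holds against azetidin-1-yl (a 2.6-fold higher number from compound 2 to compound 4 (0.41 log units; beyond the scatter)), whereas isopropoxy cannot be told apart from the new group (a 1.8-fold higher number from compound 3 to compound 4 (0.26 log units; within the scatter)). Nothing measured here accounts for this faster removal.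

As far as these compounds go, it remains open whether plain ethyl would give a number close to that of compound 4, or whether the fluorines matter. From the compounds shown here alone, a longer chain such as 3,3,3-trifluoropropyl is also untested here, so it is unknown whether the trend would continue.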